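The source may hold more compounds than are shown below. What is called first, only, known or untested is meant among the compounds shown, and "the series" means these compounds.

Working notes on the series. In a functional assay on K562 cells (Homo sapiens), read by XTT assay, with a stated time of 48 h (a lower number here means a stronger inhibitor, a higher number a weaker inhibitor), compound 2 (`CCOC(=O)c1nnn([C@@H]2O[C@H](COC(C)=O)[C@@H](OC(C)=O)[C@H]2OC(C)=O)c1-c1cccs1`) gives > 10000 nM, which is a limit of the assay and not a number. Compound 1 (`CCOC(=O)c1nnn([C@@H]2O[C@H](COC(C)=O)[C@@H](OC(C)=O)[C@H]2OC(C)=O)c1I`) gives > 10000 nM, which is likewise a limit. Among the compounds with values here, the series so far therefore stands at the limit of > 10000 nM in this assay, at which 2 of the 2 values shown sit, and compound 2 has no readable position within it.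

Compound 3 (`CCOC(=O)C#Cc1c(C(=O)OCC)nnn1[C@@H]1O[C@H](COC(C)=O)[C@@H](OC(C)=O)[C@H]1OC(C)=O`) has 2-(ethoxycarbonyl)ethynyl in place of thiophen-2-yl on an aromatic carbon, next to the ring atom that bears an ethoxycarbonyl group (2-(ethoxycarbonyl)ethynyl in place of thiophen-2-yl on an aromatic carbon). This swaps an aromatic ring for an open chain with a triple bond.

Within the data shown here, the only measured step that bears on this change is a step that the two limits leave unreadable from compound 1 to compound 2, with thiophen-2-yl in place of iodo at the same aromatic carbon. Among the measured compounds shown here, it gives no size to carry over, and no measured compound has this chain. No step beyond the scatter is therefore expected in this assay, and no direction can be assigned.

The estimated step is a step that the limit leaves unreadable from compound 2 to compound 3. Compound 3 is expected at about 12000 nM, with an estimated range of 3000 nM to 40000 nM.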

Compound 3, half-maximal inhibitory concentration: 700 nM
Beside the measured number, compound 3's estimate is 17-fold (1.23 log units) above it; measured number below the stated range.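

At the aromatic carbon next to the ring atom that bears an ethoxycarbonyl group, the choice of substituent does change the read-out in this assay: 2-(ethoxycarbonyl)ethynyl in place of thiophen-2-yl gives an at least 14-fold lower number from compound 2 to compound 3 (1.15 log units; beyond the scatter), and the same chain in place of iodo gives an at least 14-fold lower number from compound 1 to compound 3 (1.15 log units; beyond the scatter). The step between the iodo and thiophen-2-yl compounds still cannot be read, so the earlier pair gave no sign that this position could register a change, whereas the open chain with a triple bond now does. Compound 3 is the only compound shown with a readable number, and the other two values are limits: the limit of > 10000 nM in this assay, at which 2 of the 3 values shown sit.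

The compounds shown do not separate the contribution of the triple bond from that of the ester at the end of the chain, a question that a plain ethynyl group, or a chain ending in a carboxylic acid or an amide, would address. Also open, as far as these compounds go, is whether the step holds when a primary amide replaces the ethoxycarbonyl group on the neighbouring ring atom, a group that stays the same across all three compounds.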